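Two Methyl Steps on a Shared Core

The source may hold more compounds than are shown below. What is called first, only, known or untested is meant among the compounds shown, and "the series" means these compounds.

Compound 1 `COC(=O)[C@@]1(C)CCC=C2[C@@H]1CC[C@@H](C)[C@]2(C)Cc1c[nH]c2ccc(Br)cc12` gives 12000 nM in a functional assay on SW1573 cells (Homo sapiens) for inhibition, read by sulforhodamine B assay, with a stated time of 48 h; on this read-out lower numbers stand for stronger inhibition of growth and higher numbers for weaker inhibition of growth. Compound 3 `COC(=O)[C@@]1(C)CCC=C2[C@@H]1CC[C@@H](C)[C@]2(C)Cc1c(C)[nH]c2ccc(Br)cc12` gives 14000 nM in this assay; the step of a 1.2-fold higher number from compound 1 to compound 3 (0.07 log units; within the scatter) is methyl in place of hydrogen on an aromatic carbon, on a five-membered aromatic ring with one nitrogen, next to the ring nitrogen. Compound 2 `COC(=O)[C@@]1(C)CCC=C2[C@@H]1CC[C@@H](C)[C@]2(C)Cc1c(C)[nH]c2ccccc12` gives 14000 nM, and no change at the digits printed from compound 2 to compound 3 (within the scatter) is bromo in place of hydrogen on an aromatic carbon. How the cores of compound 2 and compound 1 differ is not broken down here. Compound 4 `COC(=O)[C@@]1(C)CCC=C2[C@@H]1CC[C@@H](C)[C@]2(C)Cc1c(C)[nH]c2c(C)cccc12` is not yet measured; it differs from compound 2 by methyl in place of hydrogen on an aromatic carbon, the same kind of change as before, though here on a six-membered aromatic ring of carbon only, ortho to a fused ring and meta to a fused ring. Because a 1.2-fold higher number from compound 1 to compound 3 (0.07 log units; within the scatter) stayed flat, a step of no change at the digits printed from compound 2 to compound 4 (within the scatter) is expected. Compound 4 is therefore estimated at 14000 nM in this assay.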

Compound 4, concentration for 50% growth inhibition: 15000 nM
For compound 4 the middle estimate is 1.1-fold (0.03 log units) below the measured one; measured number inside the range.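

In this assay, the new step for methyl in place of hydrogen on an aromatic carbon reads a 1.1-fold higher number from compound 2 to compound 4 (0.03 log units; within the scatter). Set beside the earlier step on the other core, the two agree: the same change on two cores in this assay, a 1.2-fold higher number (0.07 log units; within the scatter) from compound 1 to compound 3 and a 1.1-fold higher number (0.03 log units; within the scatter) from compound 2 to compound 4, 1.1-fold (0.04 log units) apart, within the scatter of two such steps. This shows that the change stayed flat on these two cores, but it does not show that it would stay flat on other cores, and the two steps sit on different rings, so these data do not separate the effect of core from that of place.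

The aromatic rings shown carry only hydrogen, methyl and bromo. As far as these compounds go, whether a longer chain, an amine or a carboxylic acid at these places would also leave the number flat remains open.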